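From a pentyl to a sec-butyl chain

The compounds below may be only part of what the source reports. "The series", "measured", "known", "first", "only" and "open" are said of these compounds alone.

Measured so far in a functional assay on LNCaP cells (Homo sapiens) for inhibition, read by WST assay, with a stated time of 3 days; on this read-out lower numbers stand for stronger inhibition and higher numbers for weaker inhibition
Compound 1 `Cn1ccnc1/C=C/C(=O)/C=C/c1coc2ccccc2c1=O` gives 2300 nM
Compound 2 `CCCCn1ccnc1/C=C/C(=O)/C=C/c1coc2ccccc2c1=O` gives 2000 nM
Compound 3 `CCCCCn1ccnc1/C=C/C(=O)/C=C/c1coc2ccccc2c1=O` gives 1800 nM

On these numbers, compound 3 cannot be told apart from the other two compounds. The data show a 1.3-fold lower number from compound 1 to compound 3 (0.11 log units; within the scatter) and a 1.1-fold lower number from compound 2 to compound 3 (0.05 log units; within the scatter) as its two steps. The next compound is compound 4 `CCC(C)n1ccnc1/C=C/C(=O)/C=C/c1coc2ccccc2c1=O` with sec-butyl in place of pentyl on an aromatic nitrogen and the rest of the structure unchanged.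

The measured steps that bear on this change are those in the chain on that same nitrogen. Besides the two already given, the data show a 1.2-fold lower number from compound 1 to compound 2 (0.06 log units; within the scatter) as a third step of similar size. All three stay small across the chains tried so far. None of the measured compounds carries a sec-butyl, so this particular change has not yet been seen directly, and the range around the estimate is kept wide for that reason.

In this assay no step beyond the scatter is expected. The estimated change is a 1.1-fold higher number from compound 3 to compound 4 (0.05 log units; within the scatter) and remains an expectation until it is measured. The expected value for compound 4 is 2000 nM with an estimated range from 1100 nM to 3500 nM (an estimate, not a measurement).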

Compound 4, half-maximal inhibitory concentration: 1300 nM
For compound 4 the middle estimate is 1.5-fold (0.19 log units) above the measured one, and the stated range covers the measured number.
By their numbers in this assay, from the lowest: compounds 4, 3, 2 and 1 (each within the scatter of the next).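

In this assay, the series now includes a branched chain on the aromatic nitrogen, and sec-butyl in place of pentyl gives a 1.4-fold lower number from compound 3 to compound 4 (0.14 log units; within the scatter), so this change stays within the scatter. Going by these compounds alone, the same holds for sec-butyl in place of the two other straight chains, with a 1.5-fold lower number from compound 2 to compound 4 (0.19 log units; within the scatter) and a 1.8-fold lower number from compound 1 to compound 4 (0.25 log units; within the scatter), and none of these steps separates compound 4 from the earlier compounds. Across methyl, butyl, pentyl and sec-butyl, this position has so far shown no measurable preference between straight and branched chains, and nothing available explains why the numbers stay so close.

From the compounds shown here alone, whether an amine or a carboxylic acid at the end of the chain, a phenyl or cyclohexyl ring on this nitrogen, or a bare hydrogen there would move the number beyond the scatter remains open. The compounds shown also keep the rest of the structure fixed, so they do not tell whether chains on this nitrogen would stay this interchangeable with other groups elsewhere on the shared core.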